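A few compounds are considered here, and "the series" means these few. Any claim that something is new, unique, unknown or untested is made for them only; others in the source may bear on it.

In a functional assay on HL-60 cells (Homo sapiens) for inhibition, read by MTT assay, with a stated time of 72 h (a lower number here means a stronger inhibitor, a higher number a weaker inhibitor), compound 3 `Cc1nc(-c2ccccc2)c(C(=O)N2CCN(c3ccc(F)cc3)CC2)o1` reads > 1000 nM, which is a limit and not a number.

Compound 4 `Cc1nc(-c2ccccc2)c(C(=O)N2CCN(c3c(C)cccc3C)CC2)o1` differs from it in one place, 2,6-dimethylphenyl in place of 4-fluorophenyl on an amine nitrogen in a ring.

Two relatives show what changing this group can do. Compound 1 `Cc1nc(-c2ccccc2)c(C(=O)N2CCN(c3cccc(Cl)c3Cl)CC2)o1`, with 2,3-dichlorophenyl, gives 133 nM, and compound 2 `Cc1ccc(C)c(N2CCN(C(=O)c3oc(C)nc3-c3ccccc3)CC2)c1`, with 2,5-dimethylphenyl, gives 31.3 nM. These two are separated by a 4.2-fold lower number from compound 1 to compound 2 (0.63 log units; beyond the scatter), so the exact group matters.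

Moving to 4-fluorophenyl gave an at least 7.5-fold higher number from compound 1 to compound 3 (0.87 log units; beyond the scatter) and an at least 31-fold higher number from compound 2 to compound 3 (1.50 log units; beyond the scatter), both beyond the scatter. Compound 2 is the nearest comparison, since it also carries a dimethylphenyl group, although the new group is 2,6-dimethylphenyl rather than 2,5-dimethylphenyl.

Running those two steps backwards points to a substantial fall in the number, meaning a stronger inhibitor. The expected step is an at least 8.3-fold lower number from compound 3 to compound 4 (0.92 log units; beyond the scatter).

For compound 4 the estimated value is 120 nM, with an expected range from 25 nM to 700 nM.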

Compound 4, half-maximal inhibitory concentration: 146 nM
For compound 4 the middle estimate is 1.2-fold (0.09 log units) below the measured one; low and high end bracket the measured number.
By their numbers in this assay, from the lowest: compound 2; then compounds 1 and 4 (each within the scatter of the next). At a limit, above all of these: compound 3.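

In this assay, leaving 4-fluorophenyl gives an at least 6.8-fold lower number from compound 3 to compound 4 (0.83 log units; beyond the scatter), which is only a bound, as the starting reading is a limit: the limit of > 1000 nM in this assay, at which 1 of the 4 values shown sits.

The arrangement of the two methyl groups matters, since 2,6-dimethylphenyl in place of 2,5-dimethylphenyl gives a 4.7-fold higher number from compound 2 to compound 4 (0.67 log units; beyond the scatter); carrying two methyl groups on the phenyl ring does not by itself fix the reading. The 2,6-dimethylphenyl and 2,3-dichlorophenyl groups cannot be told apart here, with a 1.1-fold higher number from compound 1 to compound 4 (0.04 log units; within the scatter).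

The compounds shown leave open how a single methyl group, a methoxy group or an amine on the phenyl ring would read at this position. They also leave open whether the gap between the two dimethylphenyl groups would hold on a different core.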